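The compounds below may be only part of what the source reports. "The series", "measured", "known", "first", "only" and "open" are said of these compounds alone.

Measured compounds:
compound 1 `Cc1ccc(Nc2cc(Oc3c(C)cc(Br)cc3C)c([N+](=O)[O-])cc2[N+](=O)[O-])cc1` — 53000 nM
compound 2 `Cc1cc(C)c(Oc2cc(Nc3ccc(C#N)cc3)c(N)cc2[N+](=O)[O-])c(C)c1` — 32200 nM
compound 3 `Cc1cc(C#N)cc(C)c1Oc1cc(Nc2ccc(C#N)cc2)c([N+](=O)[O-])cc1[N+](=O)[O-]` — > 58200 nM

In an ADME assay on H9 cells (Homo sapiens) for cytotoxicity, read by XTT assay, with a stated time of 6 days (a higher number here means that more compound is tolerated, a lower number that less compound is tolerated), compound 1 gives 53000 nM and compound 2 gives 32200 nM. For compound 3 the assay reports only a limit, > 58200 nM, and this is where compound 3 stands: at the limit of > 58200 nM in this assay, at which 1 of the 3 values shown sits, not at a number. For the measured compounds named here, no step between measured compounds that differ in one place is available. Compound 4 `Cc1cc(C#N)cc(C)c1Oc1ccc([N+](=O)[O-])c(Nc2ccc(C#N)cc2)c1` differs from compound 3 in one place: hydrogen in place of nitro on an aromatic carbon. With compound 3 known only as a limit, the expected step of an at least 1.1-fold lower number from compound 3 to compound 4 (0.06 log units; that floor lies within the scatter) in this assay is none beyond the usual scatter, in either direction. Compound 4 is therefore expected to give about 50000 nM in this assay, with a range from 20000 nM to 120000 nM.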

Compound 4, half-maximal cytotoxic concentration: > 65100 nM
Compound 4: no number, only a limit (the forecaster's own chance of this, stated with the estimate: 45%); middle value at least 1.3-fold (0.11 log units) away from the limit.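

Compound 3 and compound 4 are each known only as a limit in this assay, and no step can be read between them. The compounds shown leave open how far hydrogen in place of nitro on an aromatic carbon shifts the half-maximal cytotoxic concentration.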